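The source may report more compounds than this note shows. Statements on the series, on what has been measured and on what is new or still open speak of the compounds shown alone.

Working notes on the series. Of the compounds shown here, three on the shared core have been measured. Compound 1 `CCCc1cc(N)c2cc(NC(=O)/C=C/c3ccc(N)cc3)ccc2n1` gives 190 nM in an assay on isolated protein for displacement of a labelled ligand from melanin-concentrating hormone receptor 1 (Homo sapiens) (on this read-out higher numbers stand for weaker inhibition and lower numbers for stronger inhibition), the highest of the three numbers. Compound 2 `CCCc1cc(NC2CCC2)c2cc(NC(=O)/C=C/c3ccc(C(F)(F)F)cc3)ccc2n1` gives 18 nM in this assay, and compound 3 `Nc1cc(C2CCCCC2)nc2ccc(NC(=O)/C=C/c3ccc(C(F)(F)F)cc3)cc12` gives 1.2 nM; both gaps to compound 1 lie beyond the scatter, but compound 2 and compound 3 each differ from compound 1 in more than one place, so neither gap can be read as a single step.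

Compound 4 `CCCc1cc(N)c2cc(NC(=O)/C=C/c3ccccc3)ccc2n1` is not yet measured. Against compound 1 the difference is hydrogen in place of amino on an aromatic carbon. For the measured compounds named here, the measured compounds offer no step of this kind: compound 2 and compound 3 carry trifluoromethyl where compound 1 carries amino, and both give lower numbers, yet their other changes on the core leave the contribution of the amino itself unresolved. The expectation for the step from compound 1 to compound 4 is therefore cautious, a 1.7-fold higher number from compound 1 to compound 4 (0.23 log units; within the scatter), a small change toward weaker inhibition that may not clear the scatter. Compound 4 is estimated at 320 nM in this assay, within a range of 90 nM to 1200 nM.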

Compound 4, half-maximal inhibitory concentration: 1000 nM
For compound 4 the middle estimate is 3.1-fold (0.49 log units) below the measured one, and the stated range covers the measured number.
By their numbers in this assay, from the lowest: compound 3; then compound 2; then compound 1; then compound 4.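

For the compounds shown here, the change from 4-aminophenyl to phenyl gives, in this assay, a 5.3-fold higher number from compound 1 to compound 4 (0.72 log units; beyond the scatter), the first step that can be read at a single place. The position para to a large group is therefore not indifferent on this core: of the two compounds, the one with amino shows the stronger inhibition, and the step lies beyond the scatter. Nothing at hand bears on the reason for this step.

Compound 2 and compound 3 carry trifluoromethyl at this position but also differ from compound 1 elsewhere on the core, so the share of trifluoromethyl in their lower numbers remains unresolved, and a direct comparison of trifluoromethyl with amino and hydrogen on otherwise identical compounds is still needed. Also open, from the compounds shown here alone, are how other groups at this position, such as a methylamino group, a hydroxyl or a carboxylic acid, would read against amino and hydrogen, and whether the step from amino to hydrogen keeps its size when the other places on the core change.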